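Acetyl to tert-butoxycarbonyl: from compound 1 to compound 4

The source may hold more compounds than are shown below. What is called first, only, known or untested is meant among the compounds shown, and "the series" means these compounds.

Compound 1 `COc1cccc(NC(=O)c2nnn(CC3CCN(C(C)=O)CC3)c2N)c1` is the starting point in a toxicity assay on Vero cells (Chlorocebus sabaeus) for inhibition; a higher number here means that more compound is needed for the effect, a lower number that less compound is needed. Compound 1 gives > 50100 nM, which is a limit of the assay and not a number. Compound 2 `COc1cccc(NC(=O)c2nnn(Cc3ccc(C#N)cc3)c2N)c1` gives > 50100 nM, also a limit. Compound 3 `COc1cccc(NC(=O)c2nnn(Cc3ccccc3)c2N)c1` gives > 50100 nM, again a limit. The whole measured set therefore stands at one point: the limit of > 50100 nM in this assay, at which 3 of the 3 values shown sit.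

Compound 4 `COc1cccc(NC(=O)c2nnn(CC3CCN(C(=O)OC(C)(C)C)CC3)c2N)c1` keeps the core of compound 1 and differs only in acetyl to tert-butoxycarbonyl: tert-butoxy in place of methyl on a carbonyl carbon. This is tert-butoxy in place of methyl on a carbonyl carbon, whose other neighbour is an amide-type nitrogen in a ring.

For the measured compounds named here, no measured step changes the acetyl group alone. The nearest evidence is a step that the two limits leave unreadable from compound 1 to compound 2, along with a step that the two limits leave unreadable from compound 1 to compound 3 and a step that the two limits leave unreadable from compound 2 to compound 3. None of these gives a size, so the series offers no measured basis for a shift. No step beyond the scatter is expected in this assay, and no direction is assigned. The expected change is a number no higher from compound 1 to compound 4 (the limit leaves the size open). Compound 4 is estimated at 50100 nM, with an expected range from 25000 nM to 100000 nM, and the assay will probably report only a limit.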

Compound 4, half-maximal effective concentration: > 50100 nM
Compound 4 was reported as a limit (the forecaster's own chance of this, stated with the estimate: 80%); the middle value lies on the limit itself.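

In this assay compound 4 gives > 50100 nM as a limit of the assay and not a number. No step among compound 1, compound 2, compound 3 and compound 4 can be read, the new one from compound 1 to compound 4 included: the limit of > 50100 nM in this assay, at which 4 of the 4 values shown sit.

The compounds shown leave open at what concentration any of them reaches the half-maximal effect, and whether the changes on the shared core alter it.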